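The source may report more compounds than this note shows. Statements on the series, on what has been measured and on what is new or still open speak of the compounds shown alone.

Measured so far in a functional assay on the whole organism (spleen, spleen, strain LEW) for inhibition, with Rattus norvegicus as the target, with a stated time of 4 days; a lower number here means that less compound is needed, a higher number that more compound is needed for the effect:
- compound 1 `CCc1cc(CN2CC(C(=O)O)C2)sc1-c1ncc(-c2ccc(OC(C)C)c(C)c2)s1`: 0.07 mg/kg
- compound 2 `CCc1cc(CN2CC(C(=O)O)C2)sc1-c1ncc(-c2ccc(C(C)C)c(C)c2)s1`: 1.07 mg/kg

Of these two, compound 2 has the higher number, 1.07 mg/kg, so more of it is needed for the same effect. Compound 3 `CCc1cc(CN2CC(C(=O)O)C2)sc1-c1ncc(-c2ccc(O[C@@H](C)CC)c(C)c2)s1` has sec-butoxy in place of the isopropyl of compound 2 on an aromatic carbon, ortho to a methyl group (sec-butoxy in place of isopropyl on an aromatic carbon). Among the measured compounds shown here, only one measured step bears on this change: a 15-fold higher number from compound 1 to compound 2 (1.18 log units; beyond the scatter), a large step in which isopropyl replaced isopropoxy. For the measured compounds named here, compound 3 goes the other way, back to a group of the same alkoxy kind as in compound 1, although no sec-butoxy compound has been measured. A large step to a lower number in this assay is therefore expected. The estimated step is an 11-fold lower number from compound 2 to compound 3 (1.03 log units; beyond the scatter). For compound 3 the estimated value is 0.1 mg/kg, with an expected range from 0.03 mg/kg to 0.35 mg/kg.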

Compound 3, dose for 50% inhibition: 0.32 mg/kg
Compound 3: middle estimate off by 3.2-fold (0.51 log units), on the low side; low and high end bracket the measured number.
By their numbers in this assay, from the lowest: compound 1; then compound 3; then compound 2.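

In this assay, the change from isopropyl to sec-butoxy gives a 3.3-fold lower number from compound 2 to compound 3 (0.52 log units; beyond the scatter) and shows that an oxygen-linked chain on this aromatic carbon can recover part of what was lost with isopropyl. The recovery is incomplete: methyl added to the saturated chain, two bonds along from the oxygen, gives a 4.6-fold higher number from compound 1 to compound 3 (0.66 log units; beyond the scatter) and leaves isopropoxy as the best of the three groups shown, so the size or shape of the chain matters as well as the oxygen. Nothing here explains these differences.

From the compounds shown here alone, whether a shorter methoxy or ethoxy group, or a straight n-butoxy chain, would give a lower number remains open. So does the effect of the defined stereocentre, which only the opposite mirror-image form of sec-butoxy could reveal.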